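The source may hold more compounds than are shown below. What is called first, only, known or untested is meant among the compounds shown, and "the series" means these compounds.

Measured so far in an assay on isolated protein for inhibition of Nicotinamide N-methyltransferase (Homo sapiens), read by luminescence, with a stated time of 20 min; on this read-out lower numbers stand for stronger inhibition and higher numbers for weaker inhibition:
- compound 1 `C[C@H]1Cc2cc(C(N)=O)cnc2N1` gives > 10000 nM, which is a limit of the assay rather than a number.
- compound 2 `C[C@@H]1Cc2cc(C(N)=O)cnc2N1` gives 42 nM.
- compound 3 `C[C@H]1Nc2ncc(C(N)=O)cc2[C@@H]1C` gives 20 nM.

Compound 3 holds the lowest of the two numbers shown, with compound 2 nearest at a 2.1-fold lower number from compound 2 to compound 3 (0.32 log units; beyond the scatter). The unmeasured compound 4 `C[C@@H]1Nc2ncc(C(N)=O)cc2[C@H]1C` carries the same atoms and bonds as compound 3: the two compounds have the same atoms and bonds and differ only in configuration as drawn: 2 of 2 stereo elements differ (all stereocentres are inverted: mirror images); a stereocentre at a saturated ring carbon is drawn R in compound 3 and S in compound 4; a stereocentre at a saturated ring carbon is drawn S in compound 3 and R in compound 4.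

The step that bears on this is an at least 230-fold lower number from compound 1 to compound 2 (2.37 log units; beyond the scatter), a change that rests on the fact that compounds 1 and 2 differ only in the configuration as drawn alone and that reached the limit of > 10000 nM in this assay, at which 1 of the 3 values shown sits, for compound 1. Inverting a single stereocentre at a saturated ring carbon thus moved the value by a very large amount, so the assay clearly tells the two configurations apart. Compound 4 inverts both stereocentres of compound 3, and the added methyl in compound 3 only shifted the number by a 2.1-fold lower number from compound 2 to compound 3 (0.32 log units; beyond the scatter). A large step in this assay toward weaker inhibition is therefore expected for compound 4, mirroring the direction seen from compound 2 back to compound 1, and there is a real chance the assay reports only a limit.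

Compound 4 is estimated at 8000 nM in this assay, within 1500 nM to 50000 nM, which corresponds to an expected 400-fold higher number from compound 3 to compound 4 (2.60 log units; beyond the scatter).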

Compound 4, half-maximal inhibitory concentration: > 10000 nM
Compound 4 was reported as a limit (the forecaster's own chance of this, stated with the estimate: 55%); middle value at least 1.2-fold (0.09 log units) away from the limit.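

In this assay, turning compound 3 into its mirror image gives an at least 500-fold higher number from compound 3 to compound 4 (2.69 log units; beyond the scatter), and nothing but the drawn arrangement in space changes along the way: the fact that compounds 3 and 4 differ only in the configuration as drawn. Compound 4 gives > 10000 nM, which is a limit of the assay and not a number. The strong dependence on configuration that compounds 1 and 2 showed at a single stereocentre therefore also holds for a pair with two stereocentres and the extra methyl, which brings no low number back to the inverted form, while the step from compound 1 to compound 4 cannot be read, as both of its ends are limits: the limit of > 10000 nM in this assay, at which 2 of the 4 values shown sit.

Still open is which of the two stereocentres accounts for the loss, a question that a form with only one of them inverted would address. Also open, from the compounds shown here alone, is how the ring carbons would respond to a longer chain such as ethyl in place of methyl, and how the amide would compare with a carboxylic acid or a nitrile.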